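A few compounds are considered here, and "the series" means these few. Any claim that something is new, unique, unknown or untested is made for them only; others in the source may bear on it.

Compound 2 `COc1ccc2cc(CCC3(C)OCCO3)ccc2c1` carries a 2-methyl-1,3-dioxolan-2-yl group on a saturated chain carbon, two bonds along the chain from an aromatic carbon. Within the data shown here, in a functional assay on the whole organism (strain Wistar) for inhibition, with Rattus norvegicus as the target, with a stated time of 5 days, at a dose of 50 mg/kg by the oral route (a higher number here means more inhibition at the dose given (going by the name of the read-out), a lower number less inhibition), compound 2 gives 22%, the higher of the two numbers measured so far. Compound 1 `CCC(=O)CCc1ccc2cc(OC)ccc2c1` bears propanoyl at the same place and gives 7% in this assay; the step of a number 15 percentage points higher from compound 1 to compound 2 (beyond the scatter) is the only one on record. Compound 3 `COc1ccc2cc(CCC(C)O)ccc2c1` has not been measured, and its change from compound 2 is this: 1-hydroxyethyl in place of 2-methyl-1,3-dioxolan-2-yl on a saturated chain carbon, two bonds along the chain from an aromatic carbon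

Among the measured compounds shown here, no measured step exchanges a 2-methyl-1,3-dioxolan-2-yl group for 1-hydroxyethyl, and compound 1 holds propanoyl rather than either group, so the one step measured does not directly bear on this change. Without such a guide, compound 3 is expected to show a step of a number 7 percentage points lower from compound 2 to compound 3 (within the scatter) that may well fall within the scatter. The estimate for compound 3 in this assay is 15%, lying between 0% and 35%.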

Compound 3, a percentage reported as inhibition, in the whole organism at one dose (the size of the read-out at that dose, not a potency): 32%
The estimate for compound 3 lay 17 percentage points below the measured number; the measured number falls inside the stated range.
By their numbers in this assay, from the lowest: compound 1; then compounds 2 and 3 (each within the scatter of the next).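

In this assay the step from the ring-bearing 2-methyl-1,3-dioxolan-2-yl to the open-chain 1-hydroxyethyl is a number 10 percentage points higher from compound 2 to compound 3 (within the scatter), so at this place the five-membered ring can be given up without a change that stands clear of the usual scatter. Measured against propanoyl, the same new group gives a number 25 percentage points higher from compound 1 to compound 3 (beyond the scatter), which means that two different groups, not just one, now read beyond the scatter of the propanoyl compound. Nothing available here explains why these numbers fall as they do.

The compounds shown leave open how an amine or a carboxylic acid would read on this saturated chain carbon. They also leave open whether a longer chain ending in a hydroxyl group would read like compound 3 at this single dose.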